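Swapping fluoro for trifluoromethyl on two related cores

This account rests on a few compounds, and the source may have more. Where it says the series, first, only, none or still open, it means among the compounds named here.

Four compounds built around a benzimidazole-like core carrying a chain of three linked phenyl rings are compared here, and the question is how the outermost ring's substituent affects cell growth. Compound 1 `Oc1cccc2[nH]c(-c3ccc(-c4ccc(-c5ccc(F)cc5)cc4)cc3)nc12` and compound 2 `Oc1cccc2[nH]c(-c3ccc(-c4ccc(-c5ccc(C(F)(F)F)cc5)cc4)cc3)nc12` share one core; compound 3 `Cc1ccc2[nH]c(-c3ccc(-c4ccc(-c5ccc(F)cc5)cc4)cc3)nc2c1` and compound 4 `Cc1ccc2[nH]c(-c3ccc(-c4ccc(-c5ccc(C(F)(F)F)cc5)cc4)cc3)nc2c1` share another. How the two cores differ is not broken down here.

In a functional assay on PC-3 cells (Homo sapiens) for inhibition, read by sulforhodamine B assay (a lower number here means a stronger inhibitor of growth, a higher number a weaker inhibitor of growth), compound 1 gives 15300 nM, while compound 2 gives 2260 nM. The change between them, (trifluoromethyl in place of fluoro on an aromatic carbon), produced a 6.8-fold lower number from compound 1 to compound 2 (0.83 log units; beyond the scatter). Compound 3, on the second core, gives 100000 nM in this assay, the highest number of the three measured compounds, and the gap from compound 3 to compound 1 as well as to compound 2 lies beyond the scatter.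

Within the data shown here, compound 4 is related to compound 3 by trifluoromethyl in place of fluoro on an aromatic carbon, which is the same change, at the same kind of place, as the one that separated compound 1 and compound 2. The expectation for compound 4 rests on that single precedent: if the gain seen in a 6.8-fold lower number from compound 1 to compound 2 (0.83 log units; beyond the scatter) carries over to the weaker core, the step is expected to be about a 5.0-fold lower number from compound 3 to compound 4 (0.70 log units; beyond the scatter). Among the measured compounds shown here, compound 4 is therefore estimated at 20000 nM in this assay, with a plausible range from 5000 nM to 100000 nM, the wide range reflecting that only one example of the change is known and that compound 3 itself sits at a very high number.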

Compound 4, concentration for 50% growth inhibition: 2010 nM
Estimate against measurement, compound 4: 10-fold (1.00 log units) above; measured number outside the range, below it.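

In this assay, trifluoromethyl in place of fluoro gives a lower number on both cores, but the size of that gain does not carry over unchanged from one core to the other: the same change on two cores in this assay, a 6.8-fold lower number (0.83 log units; beyond the scatter) from compound 1 to compound 2 and a 50-fold lower number (1.70 log units; beyond the scatter) from compound 3 to compound 4, 7.3-fold (0.87 log units) apart, beyond the scatter of two such steps. On the second core the swap alone gives a 50-fold lower number from compound 3 to compound 4 (1.70 log units; beyond the scatter), and it brings that core level with the first, with a 1.1-fold lower number from compound 2 to compound 4 (0.05 log units; within the scatter), although the two fluoro compounds stand well apart, compound 1 at 15300 nM and compound 3 at 100000 nM. This shows that the direction of the change held in both pairs, while the step on one core was a poor guide to its size on the other; two pairs cannot establish a general rule, and these numbers alone do not explain why the steps differ.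

As far as these compounds go, it remains open whether another group on the outer ring, such as chloro, methoxy or nitrile, would also shrink the gap between the two cores. From the compounds shown here alone, it is equally open whether the same swap would give a step of either size on a core carrying an amine or a carboxylic acid in place of the hydroxy or methyl group.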